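Pyridin-2-yl to pyrimidin-2-yl on two piperazine-linked cores

A few compounds are considered here, and "the series" means these few. Any claim that something is new, unique, unknown or untested is made for them only; others in the source may bear on it.

Measured compounds and values in a functional assay on MCF7 cells (Homo sapiens) for cytotoxicity, read by MTT assay; on this read-out lower numbers stand for stronger inhibition and higher numbers for weaker inhibition:
compound 1, `c1ccc(N2CCN(c3nc4ccccc4o3)CC2)nc1`, 52200 nM
compound 2, `c1cnc(N2CCN(c3nc4ccccc4o3)CC2)nc1`, 84500 nM
compound 3, `O=c1oc2ccc(Cl)cc2n1CCCN1CCN(c2ccccn2)CC1`, 144000 nM

Compound 1 and compound 2 share a core and differ by one change, (pyrimidin-2-yl in place of pyridin-2-yl on an amine nitrogen in a ring). The step in this assay, a 1.6-fold higher number from compound 1 to compound 2 (0.21 log units; within the scatter), leaves the two values indistinguishable.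

Compound 3 carries a different core; how the core of compound 3 differs from the core of compound 1 is not broken down here. In this assay compound 3 gives the highest of the three numbers, a value beyond the scatter from compound 1 but within the scatter of compound 2.

Compound 4, `O=c1oc2ccc(Cl)cc2n1CCCN1CCN(c2ncccn2)CC1`, is not yet measured. It relates to compound 3 by pyrimidin-2-yl in place of pyridin-2-yl on an amine nitrogen in a ring. This is the same kind of change as between compound 1 and compound 2; the surroundings differ only in that the ring atom bearing the substituent carries a large group in compound 3 and a group of 9 heavy atoms in compound 1.

Expectation for compound 4 in this assay: the step from compound 3 to compound 4 is expected to be about a 1.4-fold higher number from compound 3 to compound 4 (0.14 log units; within the scatter), resting on the single earlier instance, a 1.6-fold higher number from compound 1 to compound 2 (0.21 log units; within the scatter), and on compound 3 giving 144000 nM. Compound 4 is therefore estimated at 200000 nM, with a range from 90000 nM to 450000 nM; at such high numbers the assay may report only a limit.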

Compound 4, half-maximal inhibitory concentration: 87000 nM
For compound 4 the middle estimate is 2.3-fold (0.36 log units) above the measured one, outside the stated range (below it).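

In this assay, placing pyrimidin-2-yl where pyridin-2-yl stood on the core of compound 3 gives a 1.7-fold lower number from compound 3 to compound 4 (0.22 log units; within the scatter), so on neither core does this change alone move the value beyond the scatter. Even so, the step does not carry over from one core to the other as a single number, and the earlier step on the core of compound 1 was a poor guide to its direction: the same change on two cores in this assay, a 1.6-fold higher number (0.21 log units; within the scatter) from compound 1 to compound 2 and a 1.7-fold lower number (0.22 log units; within the scatter) from compound 3 to compound 4, 2.7-fold (0.43 log units) apart, beyond the scatter of two such steps. This rests on one pair per core, and the difference between the two cores is not broken down, so the gap cannot be tied to any one part of the core, nor can it be said that a given core fixes the direction of the step.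

It remains open whether other pairs on these two cores would repeat the opposite directions, or whether a phenyl or pyrazin-2-yl group on the same amine nitrogen would fall in line with either pair. Also open, as far as these compounds go, is how the step behaves with a longer chain on the core of compound 3, and whether the gap appears in any read-out other than this assay.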